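The source may hold more compounds than are shown below. What is called first, only, known or untested is meant among the compounds shown, and "the series" means these compounds.

Measured in an ADME assay on microsomes from liver (Homo sapiens) for pharmacokinetics; on this read-out higher numbers stand for fast clearance and lower numbers for slow clearance:

- Compound 1 `Cn1cc(-c2ncc(C#N)c(N3C[C@@H]4C[C@H]3CN4CC3CC3)n2)cn1`: < 16 mL/min/kg (a limit)
- Compound 2 `C[C@@H]1CN(c2nc(-c3cnn(C)c3)ncc2C#N)CCN1C(=O)C1(C)CC1`: < 16 mL/min/kg (a limit)
- Compound 3 `C[C@@H]1CN(c2cnc(C#N)c(-c3cnn(C)c3)n2)CCN1C(=O)C1CC1`: < 16 mL/min/kg (a limit)

None of these three results is an exact number, and they all stop at the same point: the limit of < 16 mL/min/kg in this assay, at which 3 of the 3 values shown sit. Compound 2 therefore has no exact standing in this assay, and its reading of < 16 mL/min/kg is a limit of the assay. Among the compounds with values here, no measured step separates any of the three compounds.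

Compound 4 `CCC(=O)N1CCN(c2nc(-c3cnn(C)c3)ncc2C#N)C[C@H]1C` is still to be measured. It has ethyl in place of 1-methylcyclopropyl, on a carbonyl carbon whose other neighbours are: amide-type nitrogen in a ring (ethyl in place of 1-methylcyclopropyl on a carbonyl carbon). The rest of compound 2 is kept. Within the data shown here, with no measured step to go on, no change beyond the usual scatter is expected, and the expectation rests on compound 2 alone, with its limit of < 16 mL/min/kg. The estimated change is a step that the limit leaves unreadable from compound 2 to compound 4. Compound 4 is expected to come in at about 12 mL/min/kg. Its estimated range runs from 6 mL/min/kg to 22 mL/min/kg, and the assay may well report only a limit again.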

Compound 4, clearance: < 16 mL/min/kg
Compound 4: no number, only a limit; the forecaster's own chance of this, stated with the estimate: 75%; the middle value is on the limit's open side.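

Compound 2 and compound 4 both give only a limit in this assay, so no step can be read for ethyl in place of 1-methylcyclopropyl on the carbonyl carbon: the limit of < 16 mL/min/kg in this assay, at which 4 of the 4 values shown sit.

The compounds shown leave open how the clearance of any of them truly compares.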